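Aryl swap on the pyrazolone nitrogen: from compound 3 to compound 4

The compounds below may be only part of what the source reports. "The series", "measured", "known", "first", "only" and "open" are said of these compounds alone.

Compound 3 `Cc1cc(=O)n(-c2ccc(Br)cc2F)nc1C(=O)Nc1ccc(Oc2ncnc3c2ccn3C)cc1` is the reference point for this step. For the measured compounds named here, in a functional assay on MCF7 cells (Homo sapiens) for cytotoxicity, read by MTT assay, with a stated time of 72 h (a higher number here means a weaker inhibitor, a lower number a stronger inhibitor), compound 3 gives 27700 nM, the highest of the three numbers measured so far. Compound 2 `Cc1cc(=O)n(-c2ccccc2OC(F)(F)F)nc1C(=O)Nc1ccc(Oc2ncnc3c2ccn3C)cc1` gives 27000 nM in this assay, which lies within the scatter of compound 3. Compound 1 `Cc1cc(=O)n(-c2cccc(F)c2)nc1C(=O)Nc1ccc(Oc2ncnc3[nH]ccc23)cc1` gives 9670 nM in this assay, a lower number than compound 3 and beyond the scatter; compound 1 differs from compound 3 both in the aryl group on the aromatic nitrogen and elsewhere on the shared core, so no single step can be read from that pair.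

Compound 4 `Cc1cc(=O)n(-c2cccc(F)c2)nc1C(=O)Nc1ccc(Oc2ncnc3c2ccn3C)cc1` has not yet been measured. The change is 3-fluorophenyl in place of 4-bromo-2-fluorophenyl on an aromatic nitrogen, on the aromatic nitrogen next to the ring nitrogen.

Going by the values given here, the only measured step that bears on this swap of the aryl group on that nitrogen is a 1.0-fold higher number from compound 2 to compound 3 (0.01 log units; within the scatter). One exchange of the aryl group there left the number within the scatter. Compound 1 carries the same 3-fluorophenyl as compound 4 but a different core variant, and it sits lower; how much of that gap belongs to the aryl group is not separable from these data.

On this basis the step of a 1.2-fold lower number from compound 3 to compound 4 (0.06 log units; within the scatter) is expected to be small, with no direction established beyond the scatter. The estimate for compound 4 in this assay is 24000 nM, with a range from 9000 nM to 60000 nM.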

Compound 4, half-maximal inhibitory concentration: 30800 nM
For compound 4 the middle estimate is 1.3-fold (0.11 log units) below the measured one; low and high end bracket the measured number.
By their numbers in this assay, from the lowest: compound 1; then compounds 2, 3 and 4 (each within the scatter of the next).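

In this assay, the aryl exchange on the aromatic nitrogen gives a 1.1-fold higher number from compound 3 to compound 4 (0.05 log units; within the scatter), and the second exchange gives a 1.1-fold higher number from compound 2 to compound 4 (0.06 log units; within the scatter). With the earlier 1.0-fold higher number from compound 2 to compound 3 (0.01 log units; within the scatter), this places 3-fluorophenyl, 4-bromo-2-fluorophenyl and 2-(trifluoromethoxy)phenyl within the scatter of one another on the shared core, so no aryl group shown here separates from the others in this assay. With 3-fluorophenyl held constant, methyl in place of hydrogen on an aromatic nitrogen gives a 3.2-fold higher number from compound 1 to compound 4 (0.50 log units; beyond the scatter), which is the only single-place step shown that lies beyond the scatter and is modest in size.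

Going by these compounds, it remains open whether the hydrogen of compound 1 would give a similar gap when paired with 4-bromo-2-fluorophenyl or 2-(trifluoromethoxy)phenyl, and whether an amine or a carboxylic acid on the phenyl ring would move the number at all. No supporting measurement is available to explain either the aryl steps or the methyl step.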